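The source may hold more compounds than are shown below. What is called first, only, known or untested is meant among the compounds shown, and "the series" means these compounds.

In a functional assay on HepG2 cells (Homo sapiens) for antiproliferative activity, read by MTT assay, with a stated time of 24 h (on this read-out higher numbers stand for weaker inhibition and lower numbers for stronger inhibition), three compounds have been measured so far.
Compound 1 `Fc1ccc(C2CC(c3ccccc3)=NN2c2ccc(-c3ccccc3)nn2)cc1` gives 8420 nM.
Compound 2 `COc1ccc(C2=NN(c3ccc(-c4ccccc4)nn3)C(c3ccc(F)cc3)C2)cc1` gives 9160 nM.
Compound 3 `COc1ccc(C2=NN(c3ccc(-c4ccccc4)nn3)C(c3ccc(OC)cc3)C2)cc1` gives only a limit of the assay, > 100000 nM.

The change from compound 1 to compound 2 is methoxy in place of hydrogen on an aromatic carbon, and it made a 1.1-fold higher number from compound 1 to compound 2 (0.04 log units; within the scatter). The next change, methoxy in place of fluoro on an aromatic carbon, made an at least 10-fold higher number from compound 2 to compound 3 (1.03 log units; beyond the scatter), so that compound 3 sits at the limit of > 100000 nM in this assay, at which 1 of the 3 values shown sits. How the core of compound 3 differs from the core of compound 1 is not broken down here.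

Compound 4 `COc1ccc(C2=NN(c3ccc(-c4ccccc4)nn3)C(c3ccc(OC)cc3OC)C2)cc1` differs from compound 3 by methoxy in place of hydrogen on an aromatic carbon. This is the same kind of change as from compound 1 to compound 2, but not the same: there the methoxy sat para to a large group, whereas here it sits ortho to a large group and meta to a methoxy group. Compound 4 is expected to show a step that the limit leaves unreadable from compound 3 to compound 4, because a 1.1-fold higher number from compound 1 to compound 2 (0.04 log units; within the scatter) lay within the scatter. Compound 4 is therefore estimated at 150000 nM, between 60000 nM and 400000 nM, and is expected to return again only a limit of the assay.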

Compound 4, half-maximal inhibitory concentration: > 100000 nM
Compound 4 was reported as a limit (the forecaster's own chance of this, stated with the estimate: 75%); the middle value does not contradict the limit.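

On the core of compound 1, methoxy in place of hydrogen gave a 1.1-fold higher number from compound 1 to compound 2 (0.04 log units; within the scatter). The same kind of change, 4-methoxyphenyl to 2,4-dimethoxyphenyl, cannot be read from compound 3 to compound 4, since both are reported only as a limit: the limit of > 100000 nM in this assay, at which 2 of the 4 values shown sit. So whether the change carries over from one core to the other is neither shown nor ruled out, and the one readable result in this assay is an at least 10-fold higher number from compound 2 to compound 4 (1.03 log units; beyond the scatter), with 2,4-dimethoxyphenyl in place of 4-fluorophenyl.

Still open, as far as these compounds go, is whether another group on this ring, such as an amine or a carboxylic acid, would give a measurable number rather than a limit.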